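Replacing trifluoromethyl with methyl on the shared core

A few compounds are considered here, and "the series" means these few. Any claim that something is new, unique, unknown or untested is made for them only; others in the source may bear on it.

Compound 1 `COc1cc(-c2nccn3cc(-c4ccc(F)cc4)nc23)cc(OC)c1OC`: 217 nM
Compound 2 `COc1cc(-c2nccn3cc(-c4ccc([N+](=O)[O-])cc4)nc23)cc(OC)c1OC`: > 10000 nM
Compound 3 `COc1cc(-c2nccn3cc(-c4ccc(C(F)(F)F)cc4)nc23)cc(OC)c1OC`: 2630 nM

All three results come from a functional assay on HepG2 cells (Homo sapiens) for inhibition, read by MTT assay, with a stated time of 48 h; a lower number here means a stronger inhibitor, a higher number a weaker inhibitor. For compound 2, the entry > 10000 nM is a limit of the assay and not a number. Going by the values given here, only two true numbers therefore exist, and compound 3 holds the higher of them, with 2630 nM. Its nearest neighbour is compound 1, with 217 nM.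

Compound 4 `COc1cc(-c2nccn3cc(-c4ccc(C)cc4)nc23)cc(OC)c1OC` has methyl in place of trifluoromethyl on an aromatic carbon, para to a large group: methyl in place of trifluoromethyl on an aromatic carbon. Among the compounds with values here, no measured step makes this exchange directly, so the evidence is indirect. Within the data shown here, the comparison with the fluoro compound shows a 12-fold higher number from compound 1 to compound 3 (1.08 log units; beyond the scatter), and the one with the nitro compound shows an at least 3.8-fold lower number from compound 2 to compound 3 (0.58 log units; beyond the scatter). The widest comparison shows an at least 46-fold higher number from compound 1 to compound 2 (1.66 log units; beyond the scatter). Thus the number moved well beyond the scatter each time this group changed, and compound 1 remains the strongest of the three. These steps suggest that the position is sensitive, but they do not place methyl on the scale. A drop of moderate size seems likely, smaller than the full distance to compound 1.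

The expected step is a 3.3-fold lower number from compound 3 to compound 4 (0.52 log units; beyond the scatter). The estimated value for compound 4 is 800 nM, with an expected range from 200 nM to 4000 nM.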

Compound 4, half-maximal inhibitory concentration: 160 nM
Beside the measured number, compound 4's estimate is 5.0-fold (0.70 log units) above it; measured number below the stated range.
By their numbers in this assay, from the lowest: compounds 4 and 1 (each within the scatter of the next); then compound 3. At a limit, above all of these: compound 2.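

In this assay, the exchange of trifluoromethyl for methyl gives a 16-fold lower number from compound 3 to compound 4 (1.22 log units; beyond the scatter), which shows that this place on the 4-substituted phenyl ring can carry a carbon group and still give a low number, something the earlier compounds had shown only for fluoro. Compound 4 and compound 1 cannot be told apart, with a 1.4-fold lower number from compound 1 to compound 4 (0.13 log units; within the scatter), so the low number at this position is no longer tied to fluoro alone, and trifluoromethyl and methyl, both carbon groups, lie far apart. The widest new gap is an at least 62-fold lower number from compound 2 to compound 4 (1.79 log units; beyond the scatter), and it is only a bound, with compound 2 standing at a limit of the assay and not at a number: the limit of > 10000 nM in this assay, at which 1 of the 4 values shown sits.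

As far as these compounds go, whether the low numbers hold for other groups at this place, such as ethyl, methoxy or an amine, stays open. Also open is why methyl and fluoro give numbers within the scatter of each other while trifluoromethyl does not, and four compounds in this assay offer no ground for naming a cause.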